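Working notes: methoxy in place of methyl

This account rests on a few compounds, and the source may have more. Where it says the series, first, only, none or still open, it means among the compounds named here.

- compound 1 `O=C1/C(=C/c2cccc(Cl)c2)Cc2ccccc21`: 26300 nM
- compound 2 `Cc1cccc(/C=C2\Cc3ccccc3C2=O)c1`: 24900 nM

Both values come from a functional assay on P388 cells (Mus musculus) for inhibition (a higher number here means a weaker inhibitor, a lower number a stronger inhibitor), and they lie within the scatter of each other, so compound 2 cannot be separated from compound 1. The next structure is compound 3 `COc1cccc(/C=C2\Cc3ccccc3C2=O)c1`, with the change methoxy in place of methyl on an aromatic carbon, meta to a large group. Among the measured compounds shown here, only one measured step bears on this: a 1.1-fold lower number from compound 1 to compound 2 (0.02 log units; within the scatter), for methyl in place of chloro on an aromatic carbon. For the measured compounds named here, no measured step involves methoxy, so this evidence is thin. With that single step inside the scatter, no clear shift in this assay is expected, and neither direction is favoured. The expected step is a 1.0-fold higher number from compound 2 to compound 3 (0.00 log units; within the scatter). For compound 3 the estimate is 25000 nM, with an expected range of 10000 nM to 60000 nM.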

Compound 3, half-maximal inhibitory concentration: > 50000 nM
Compound 3 was reported as a limit (the forecaster's own chance of this, stated with the estimate: 10%); middle value at least 2.0-fold (0.30 log units) from the limit.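

Compound 3 is reported in this assay only as a limit, > 50000 nM. Read as floors, the record gives an at least 2.0-fold higher number from compound 2 to compound 3 (0.30 log units; that floor lies within the scatter) and an at least 1.9-fold higher number from compound 1 to compound 3 (0.27 log units; that floor lies within the scatter), so unlike methyl in place of chloro, methoxy on this aromatic carbon, meta to a large group, gives a step with no upper bound, though its floor does not establish a real loss. The series holds one value of this kind, which can only be read as a floor: the limit of > 50000 nM in this assay, at which 1 of the 3 values shown sits.

Still open, going by these compounds, is whether the true number for compound 3 lies beyond the scatter of compound 1 and compound 2. A hydroxy or an ethyl group on the same aromatic carbon would separate the contribution of the oxygen from that of the chain length.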